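The source may hold more compounds than are shown below. What is called first, only, known or untested is meant among the compounds shown, and "the series" means these compounds.

Measured so far in a functional assay on HT-29 cells (Homo sapiens) for cytotoxicity; on this read-out lower numbers stand for stronger inhibition and higher numbers for weaker inhibition:
Compound 1 `Nc1nn(Cc2ccccc2)c2nnc(-c3ccccc3)c(-c3ccccc3)c12`: > 100000 nM
Compound 2 `O=C(Nc1ccccc1)Nc1[nH]nc2nnc(-c3ccccc3)c(-c3ccccc3)c12`: > 100000 nM

Neither entry is a number. The reading for compound 1 is a limit of the assay, > 100000 nM. The reading for compound 2 is also a limit of the assay, > 100000 nM. As far as these compounds go, compound 1 therefore stands at the limit of > 100000 nM in this assay, at which 2 of the 2 values shown sit, and its true position beyond that limit is unknown.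

Compound 3 `Nc1nn(COCCO)c2nnc(-c3ccccc3)c(-c3ccccc3)c12` has 2-hydroxyethoxy in place of phenyl on a saturated chain carbon bound to an aromatic nitrogen. The same difference, cut one bond further out, reads benzyl to (2-hydroxyethoxy)methyl.

Among the compounds with values here, no measured pair differs in one place only, so no measured step can serve as a guide. The expected step of a number no higher from compound 1 to compound 3 (the limit leaves the size open) in this assay is none beyond the scatter, with no direction favoured. This expectation rests on compound 1, whose limit is > 100000 nM. A reading at the same limit is the likeliest outcome. For compound 3 the estimated value is 100000 nM, with an expected range from 30000 nM to 200000 nM.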

Compound 3, half-maximal inhibitory concentration: > 100000 nM
Compound 3: a limit, no number (the forecaster's own chance of this, stated with the estimate: 80%); the middle value sits exactly at the limit.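

Compound 3 gives > 100000 nM in this assay, which is a limit and not a number. Within the data shown here, compound 1 also stands at a limit, so no step between the two compounds can be read: the limit of > 100000 nM in this assay, at which 3 of the 3 values shown sit.

The compounds shown leave open whether any change to the shared core gives a number in this assay and how far each compound lies beyond its limit.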